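This account rests on a few compounds, and the source may have more. Where it says the series, first, only, none or still open, it means among the compounds named here.

Measured in a functional assay on NCI-H1650 cells (Homo sapiens) for cytotoxicity, read by MTT assay, with a stated time of 72 h; on this read-out lower numbers stand for stronger inhibition and higher numbers for weaker inhibition:
Compound 1 `O=C1/C(=C/c2ccccc2)COC/C1=C\c1ccccc1F`: 9600 nM
Compound 2 `COc1cc(/C=C2\COC/C(=C\c3ccccc3F)C2=O)ccc1O`: 18500 nM

On these numbers, compound 1 cannot be separated from compound 2, since their two values lie within the usual scatter of each other. Compound 3 `O=C1/C(=C/c2ccccc2F)COC/C1=C\c1ccc(Cl)cc1Cl` has not yet been measured. It departs from compound 1 by one change, with 2,4-dichlorophenyl in place of phenyl on a double-bonded chain carbon bound to a double-bonded ring carbon. Going by the values given here, no measured pair differs in one place only, so the data give no direct guide to this change. The only anchor is the narrow spread of the two measured values, with compound 1 at 9600 nM and compound 2 at 18500 nM. No step beyond the scatter is expected, and the estimate is a 1.4-fold lower number from compound 1 to compound 3 (0.14 log units; within the scatter). For compound 3 the estimated value is 7000 nM, with an expected range from 2500 nM to 20000 nM.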

Compound 3, half-maximal inhibitory concentration: 8600 nM
Compound 3: middle estimate off by 1.2-fold (0.09 log units), on the low side, within the range that was stated.
By their numbers in this assay, from the lowest: compounds 3, 1 and 2 (each within the scatter of the next, the first and the last beyond it).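

In this assay the replacement of phenyl by 2,4-dichlorophenyl on a double-bonded chain carbon bound to a double-bonded ring carbon gives a 1.1-fold lower number from compound 1 to compound 3 (0.05 log units; within the scatter) and so leaves compound 1 and compound 3 indistinguishable. Going by these compounds alone, this is the first direct reading of a single replacement at this position, which the earlier compounds could not provide, and it shows that the larger, chlorine-bearing ring is accepted here without a step beyond the scatter. No supporting measurement bears on why this is so.

The compounds shown leave open whether either chlorine alone would read the same as the pair. They also leave open whether a group of another kind on this ring, such as an amine or a carboxylic acid, would give a step beyond the scatter.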